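Removing a methyl group: compound 3 to compound 4

The source may report more compounds than this note shows. Statements on the series, on what has been measured and on what is new or still open speak of the compounds shown alone.

The series is measured in a functional assay on HeLa cells (Homo sapiens) for cytotoxicity, read by MTT assay, with a stated time of 72 h; on this read-out higher numbers stand for weaker inhibition and lower numbers for stronger inhibition. Compound 1 `N/C(=N\NC(=S)N1CCSCC1)c1ccccn1` gives 7800 nM in this assay, compound 2 `Cc1cccc(/C(N)=N/NC(=S)N2CCCCC2)n1` gives 2000 nM, and compound 3 `Cc1ccnc(/C(N)=N/NC(=S)N2CCCCC2)c1` gives 7700 nM. Among these three numbers compound 3 stands second highest; its nearest neighbour is compound 1, whose number lies within the scatter of it, while compound 2 sits furthest away, with a number that is beyond the scatter lower.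

Compound 4 `N/C(=N\NC(=S)N1CCCCC1)c1ccccn1` has not yet been measured in this assay. It differs from compound 3 in one place: hydrogen in place of methyl on an aromatic carbon. The change is small, a single carbon leaving from an aromatic carbon of a six-membered aromatic ring with 1 nitrogen, meta to a large group and opposite the ring nitrogen. For the measured compounds named here, no measured pair shows this exact change, so the expected step rests on the size of the change alone: the step from compound 3 to compound 4 is expected to be small, a 1.1-fold lower number from compound 3 to compound 4 (0.04 log units; within the scatter), with no clear direction beyond the scatter. Compound 4 is therefore estimated at 7000 nM, within a range from 3000 nM to 17000 nM.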

Compound 4, half-maximal inhibitory concentration: 3800 nM
Compound 4: middle estimate off by 1.8-fold (0.27 log units), on the high side; measured number inside the range.
By their numbers in this assay, from the lowest: compounds 2 and 4 (each within the scatter of the next); then compounds 3 and 1 (each within the scatter of the next).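

On the read-out of this assay, taking the methyl away from the aromatic carbon opposite the ring nitrogen gives a modest step beyond the scatter (a 2.0-fold lower number from compound 3 to compound 4 (0.31 log units; beyond the scatter)), the first sign that a methyl at this position goes with a weaker result. The same replacement of methyl by hydrogen on the other methylated ring stays within the scatter (a 1.9-fold higher number from compound 2 to compound 4 (0.28 log units; within the scatter)), so among these two pairs the outcome depends on where the methyl sits. Piperidin-1-yl in place of thiomorpholin-4-yl on the thiocarbonyl carbon also gives a modest step beyond the scatter (a 2.1-fold lower number from compound 1 to compound 4 (0.31 log units; beyond the scatter)). Nothing at hand explains why the two methyl placements differ. Open, as far as these compounds go, is how an ethyl, a methoxy or an amine would read on that aromatic carbon, and how morpholin-4-yl would read on the thiocarbonyl carbon.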